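From 4-hydroxyphenyl to 4-hydroxybenzyl on the amide-type nitrogen

The compounds below may be only part of what the source reports. "The series", "measured", "known", "first", "only" and "open" are said of these compounds alone.

In an ADME assay on MT4 cells (Homo sapiens) for cytotoxicity, read by MTT assay (on this read-out higher numbers stand for lower toxicity in this test and lower numbers for higher toxicity in this test), compound 1 `Cc1cc(C)cc(S(=O)(=O)c2c(C(=O)Nc3ccc(O)cc3)[nH]c3ccc(Cl)cc23)c1` gives 18100 nM. Compound 2 `Cc1cc(C)cc(S(=O)(=O)c2c(C(=O)NCc3ccccc3O)[nH]c3ccc(Cl)cc23)c1` gives 23800 nM, and the measured step of a 1.3-fold higher number from compound 1 to compound 2 (0.12 log units; within the scatter) leaves the two level. Compound 3 `Cc1cc(C)cc(S(=O)(=O)c2c(C(=O)NCc3cc(O)ncn3)[nH]c3ccc(Cl)cc23)c1` reads > 53000 nM, which is a limit of the assay and not a number. Compound 1 therefore stands level with compound 2 and apart from that limit, with a step of an at least 2.9-fold higher number from compound 1 to compound 3 (0.46 log units; beyond the scatter).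

Compound 4 `Cc1cc(C)cc(S(=O)(=O)c2c(C(=O)NCc3ccc(O)cc3)[nH]c3ccc(Cl)cc23)c1` has 4-hydroxybenzyl in place of 4-hydroxyphenyl on an amide-type nitrogen. For the measured compounds named here, the closest precedent is compound 2, which brought 2-hydroxybenzyl onto the same nitrogen with the step of a 1.3-fold higher number from compound 1 to compound 2 (0.12 log units; within the scatter). The step of an at least 2.2-fold higher number from compound 2 to compound 3 (0.34 log units; beyond the scatter) bears less directly, as it brings in 6-hydroxypyrimidin-4-yl, a group absent from compound 4. In this assay no change beyond the scatter is therefore expected, and the estimated step is a 1.2-fold higher number from compound 1 to compound 4 (0.08 log units; within the scatter). For compound 4 the expected value is 22000 nM, with an estimated range of 12000 nM to 42000 nM.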

Compound 4, half-maximal cytotoxic concentration: 6250 nM
The estimate for compound 4 lay 3.5-fold (0.55 log units) above the measured number, and the stated range ends above it.
By their numbers in this assay, from the lowest: compound 4; then compounds 1 and 2 (each within the scatter of the next). At a limit, above all of these: compound 3.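

In this assay the change from 4-hydroxyphenyl to 4-hydroxybenzyl on this amide-type nitrogen is not neutral: it gives a 2.9-fold lower number from compound 1 to compound 4 (0.46 log units; beyond the scatter) and so departs from the level step seen with 2-hydroxybenzyl. The two hydroxybenzyl compounds do not behave as one group, since 4-hydroxyphenyl in place of 2-hydroxyphenyl on the chain carbon gives a 3.8-fold lower number from compound 2 to compound 4 (0.58 log units; beyond the scatter) and leaves compound 4 with the lowest number of the series, the highest toxicity in this test. Compound 3 reads a limit and not a number, and its 6-hydroxypyrimidin-4-yl exchanged for 4-hydroxyphenyl gives an at least 8.4-fold lower number from compound 3 to compound 4 (0.92 log units; beyond the scatter).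

Nothing shown here accounts for these steps. Open, as far as these compounds go, is whether 3-hydroxybenzyl, 4-methoxybenzyl or 4-aminobenzyl on the same nitrogen would read with compound 2 or with compound 4, and what a longer chain such as 2-(4-hydroxyphenyl)ethyl would give.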